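The compounds below may be only part of what the source reports. "The series", "measured", "known", "first", "only" and "open" are said of these compounds alone.

Measured in a functional assay on MCF7 cells (Homo sapiens) for cytotoxicity, read by MTT assay; a lower number here means a stronger inhibitor, a higher number a weaker inhibitor:
- compound 1 `COc1ccc(OC)c(C(=O)/C=C/c2ccoc2)c1`: 18200 nM
- compound 2 `COc1ccc(OC)c(C(=O)/C=C/c2ccc(OC(=O)/C=C/c3ccc(C)cc3)cc2)c1`: 12600 nM

These two values lie within the usual scatter of each other, so compound 2 cannot be told apart from compound 1 on these numbers. Compound 3 `COc1ccc(OC)c(C(=O)/C=C/c2ccc(OC(=O)/C=C/c3cc(OC)c(OC)c(OC)c3)cc2)c1` keeps the rest of compound 2 and makes one change: 3,4,5-trimethoxyphenyl in place of 4-methylphenyl on a double-bonded chain carbon bound to a double-bonded chain carbon. Within the data shown here, no measured pair shows what this change does. A modest move toward a lower number in this assay is expected, possibly not beyond the scatter. The estimated size of this move is a 1.7-fold lower number from compound 2 to compound 3 (0.23 log units; within the scatter). For compound 3 the estimate is 7500 nM, with an expected range from 2500 nM to 22000 nM.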

Compound 3, half-maximal inhibitory concentration: 6400 nM
Beside the measured number, compound 3's estimate is 1.2-fold (0.07 log units) above it; low and high end bracket the measured number.
By their numbers in this assay, from the lowest: compounds 3, 2 and 1 (each within the scatter of the next, the first and the last beyond it).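

Placing 3,4,5-trimethoxyphenyl, with its 12 heavy atoms and 3 hydrogen-bond acceptors, in place of 4-methylphenyl on a double-bonded chain carbon bound to a double-bonded chain carbon gives a 2.0-fold lower number from compound 2 to compound 3 (0.29 log units; within the scatter) in this assay. This position therefore takes the bigger group without any change that can be told from scatter. Nothing measured here gives a cause for this step. As far as these compounds go, whether a phenyl ring carrying an amine, a carboxylic acid or a single methoxy group would move the number beyond the scatter stays open. One step at this place sets no trend.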